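Para-Linked Analogue: Will Tolerance Survive the Methyl Shift?

The source may report more compounds than this note shows. Statements on the series, on what has been measured and on what is new or still open speak of the compounds shown alone.

Measured compounds: compound 1 `Cc1ccccc1-n1cc(-c2ccccc2NS(=O)(=O)c2c[nH]c(=O)[nH]c2=O)nn1` at 56600 nM; compound 2 `Cc1cccc(-n2cc(-c3ccccc3NS(=O)(=O)c3c[nH]c(=O)[nH]c3=O)nn2)c1` at 21900 nM; compound 3 `Cc1ccccc1-n1cc(-c2ccc(NS(=O)(=O)c3c[nH]c(=O)[nH]c3=O)cc2)nn1`, recorded as "not toxic" (no number reported).

In an ADME assay on L02 cells (Homo sapiens) for cytotoxicity, read by MTT assay, with a stated time of 24 h (a lower number here means that less compound is tolerated, a higher number that more compound is tolerated), compound 1 and compound 2 share a core and differ only in 3-methylphenyl in place of 2-methylphenyl on an aromatic nitrogen; this gave a 2.6-fold lower number from compound 1 to compound 2 (0.41 log units; beyond the scatter). Compound 3 carries a different core; the difference between the two cores is not broken down here. Compound 3 gave no single number in this assay. Compound 4 `Cc1cccc(-n2cc(-c3ccc(NS(=O)(=O)c4c[nH]c(=O)[nH]c4=O)cc3)nn2)c1`, not yet measured, relates to compound 3 exactly as compound 2 relates to compound 1: 3-methylphenyl in place of 2-methylphenyl on an aromatic nitrogen is the same change. Within the data shown here, a step of similar size is expected here, resting on the one example from compound 1 to compound 2, though with no number for compound 3 the starting point is uncertain. Compound 4 is estimated at 100000 nM, expected between 30000 nM and 300000 nM.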

Compound 4, half-maximal cytotoxic concentration: 39000 nM
Compound 4: middle estimate off by 2.6-fold (0.41 log units), on the high side; the range from low to high includes it.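

Compound 3 has no number in this assay and the change from compound 3 to compound 4 therefore cannot be read as a step. Whether 3-methylphenyl in place of 2-methylphenyl lowers the number on this core as well stays open, and nothing at hand explains these values.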